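The source may hold more compounds than are shown below. What is called first, only, known or untested is meant among the compounds shown, and "the series" means these compounds.

Measured so far in an assay on CHO cells for displacement of a labelled ligand from adenosine receptor A1 (Homo sapiens), read by scintillation counting, with a stated time of 60 min, tested at 10 uM; a lower number here means less inhibition, a higher number more inhibition at the concentration tested (going by the name of the read-out):
Compound 1 `COc1cccc2cc(C(=O)NCC(=O)O)c(=O)oc12` gives 27%.
Compound 2 `COc1cccc2cc(C(=O)N[C@@H](CO)C(=O)O)c(=O)oc12` gives 12%.

Within the data shown here, compound 2 stands lowest of these two numbers; its nearest neighbour is compound 1, and the single change between them, hydroxymethyl in place of hydrogen on a saturated chain carbon bound to an amide-type nitrogen and a carbonyl carbon, gave a number 15 percentage points lower from compound 1 to compound 2 (beyond the scatter). Compound 3 `COCCNC(=O)c1cc2cccc(OC)c2oc1=O` is not yet measured. It differs from compound 2 by 2-methoxyethyl in place of 1-carboxy-2-hydroxyethyl on an amide-type nitrogen. Among the measured compounds shown here, only the step from compound 1 to compound 2 bears on this change, and only loosely: that step added a hydroxymethyl and took nothing away, whereas the change to compound 3 removes the carboxy and the hydroxyl together and brings in a methoxyethyl chain. That step was modest, so a modest shift in this assay is expected for compound 3, most plausibly upward toward compound 1, as a number 12 percentage points higher from compound 2 to compound 3 (beyond the scatter). Compound 3 is therefore estimated at 24%, within a range from 5% to 50%.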

Compound 3, a percentage reported as inhibition, at one concentration (the size of the read-out at that concentration, not a potency): 45%
Compound 3: middle estimate off by 21 percentage points, on the low side; the measured number falls inside the stated range.
By their numbers in this assay, from the lowest: compound 2; then compound 1; then compound 3.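

In this assay, putting 2-methoxyethyl in place of 1-carboxy-2-hydroxyethyl on the amide-type nitrogen gave a number 33 percentage points higher from compound 2 to compound 3 (beyond the scatter) and is a large change, whereas the earlier step at this position was only modest. Methoxymethyl in place of carboxy on the saturated chain carbon gave a number 18 percentage points higher from compound 1 to compound 3 (beyond the scatter) and shows that a side chain without the carboxy gives the highest of the three numbers, so this position can move the read-out upward as well as downward. No measurement here explains why the number rose.

On these data alone, compound 2 and compound 3 differ in both the carboxy and the hydroxyl at once, so the share of each remains unknown. As far as these compounds go, whether the ether oxygen matters also remains open, and a plain propyl chain, a longer alkoxy chain or a chain ending in an amine would address that question.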